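A Bromo for Methyl Swap on a Weakly Active Sulfone

The source may hold more compounds than are shown below. What is called first, only, known or untested is meant among the compounds shown, and "the series" means these compounds.

Compound 1 `COc1ccc(Nc2nc3ccccc3nc2S(=O)(=O)c2ccc(C)cc2)cc1` is tested in a functional assay on A549 cells (Homo sapiens) for cytotoxicity, read by MTT assay, with a stated time of 72 h; on this read-out higher numbers stand for weaker inhibition and lower numbers for stronger inhibition. For compound 1 the assay reports only a limit, > 50000 nM. Its two measured companions alter the group on the aniline ring: compound 2 `Cc1ccc(S(=O)(=O)c2nc3ccccc3nc2Nc2ccc(N)cc2)cc1` gives 24600 nM and compound 3 `Cc1ccc(S(=O)(=O)c2nc3ccccc3nc2Nc2ccc(C(F)(F)F)cc2)cc1` gives 13500 nM. The step of an at least 2.0-fold lower number from compound 1 to compound 2 (0.30 log units; that floor lies within the scatter) and the step of an at least 3.7-fold lower number from compound 1 to compound 3 (0.56 log units; beyond the scatter) both lead away from that limit (the limit of > 50000 nM in this assay, at which 1 of the 3 values shown sits). Compound 4 `COc1ccc(Nc2nc3ccccc3nc2S(=O)(=O)c2ccc(Br)cc2)cc1` differs from compound 1 elsewhere: bromo in place of methyl on an aromatic carbon. Among the measured compounds shown here, no measured step touches the sulfonyl-bearing ring, so the measured steps bear on this change only by showing that the shared core sits near the limit, and no shift beyond the scatter is expected in this assay. Compound 4 is therefore expected at 40000 nM, within 10000 nM to 160000 nM, a step of an at least 1.2-fold lower number from compound 1 to compound 4 (0.09 log units; that floor lies within the scatter).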

Compound 4, half-maximal inhibitory concentration: 3340 nM
Estimate against measurement, compound 4: 12-fold (1.08 log units) above; measured number below the stated range.
By their numbers in this assay, from the lowest: compound 4; then compounds 3 and 2 (each within the scatter of the next). At a limit, above all of these: compound 1.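

The 4-methylphenyl to 4-bromophenyl change gives an at least 14-fold lower number from compound 1 to compound 4 (1.17 log units; beyond the scatter) in this assay. Among the compounds shown here, this shows that the sulfonyl-bearing ring, which no earlier step touched, is a place where one group can move the number well beyond the scatter. Compound 1 remains a limit, so this step gives only a floor: the limit of > 50000 nM in this assay, at which 1 of the 4 values shown sits.

From the compounds shown here alone, whether chloro, a nitrile or an amine at this position would act as bromo does remains open. So does whether bromo gives a similar step when amino or trifluoromethyl replaces methoxy on the aniline ring.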